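The source may report more compounds than this note shows. Statements on the series, on what has been measured and on what is new or still open speak of the compounds shown alone.

In a physicochemical assay for solubility, in phosphate buffer, at pH 7.4 (a lower number here means a less soluble compound, a higher number a more soluble compound), compound 1 `CCOC(=O)c1c(-c2ccc(C(F)(F)F)cc2)[nH]c2cccc(OC)c2c1=O` gives 22000 nM. Compound 3 `CCOC(=O)c1c(-c2ccc(OC)cc2)[nH]c2cccc(OC)c2c1=O` gives > 100000 nM, which is a limit of the assay and not a number. Compound 2 `CCOC(=O)c1c(-c2cccc(F)c2)[nH]c2cc(OC)ccc2c1=O` gives > 100000 nM, also only a limit. The readings thus stop at the limit of > 100000 nM in this assay, at which 2 of the 3 values shown sit. Compound 4 `CCOC(=O)c1c(-c2ccccc2Cl)[nH]c2cc(OC)ccc2c1=O` carries 2-chlorophenyl in place of 3-fluorophenyl on an aromatic carbon. For the measured compounds named here, the only measured step, an at least 4.5-fold higher number from compound 1 to compound 3 (0.65 log units; beyond the scatter), replaces trifluoromethyl with methoxy, so it bears on this change only loosely, though it shows that one group can move this read-out beyond the scatter. A modest fall in the number is expected, with a reading at the limit still possible. The expected change is an at least 1.6-fold lower number from compound 2 to compound 4 (0.22 log units; that floor lies within the scatter). Compound 4 is estimated at 60000 nM, within a range of 20000 nM to 100000 nM.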

Compound 4, solubility: 28000 nM
Compound 4: the middle estimate sits 2.1-fold (0.33 log units) above what was measured; low and high end bracket the measured number.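

With the change from 3-fluorophenyl to 2-chlorophenyl on the core of compound 2, this assay gives an at least 3.5-fold lower number from compound 2 to compound 4 (0.55 log units; beyond the scatter). This shows that the aryl group on this carbon, next to the ring nitrogen, can move the read-out beyond the scatter on this core too, and that the change brings a reading inside the limit. The step is only a floor because compound 2 gives a limit and not a number: the limit of > 100000 nM in this assay, at which 2 of the 4 values shown sit.

The compounds shown leave open whether the halogen or its place on the phenyl ring carries this step. They also leave open how an amine or a carboxylic acid on that phenyl ring would read.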